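A dioxolane group gives way to an oxolane ring

The source may report more compounds than this note shows. Statements on the series, on what has been measured and on what is new or still open speak of the compounds shown alone.

Within the data shown here, in a functional assay on A549 cells (Homo sapiens) for cytotoxicity, read by MTT assay, with a stated time of 72 h (a higher number here means a weaker inhibitor, a lower number a stronger inhibitor), compound 2 `CC1(C)O[C@@H](CO)[C@H](Cn2cc(Cn3c4c(c5ccccc53)C(=O)c3c[n+]([O-])c5ccccc5c3C4=O)nn2)O1` gives 370 nM and so holds the lower of the two numbers measured so far, against compound 1 `O=C1c2c[n+]([O-])c3ccccc3c2C(=O)c2c1c1ccccc1n2Cc1cn(CC(O)CO)nn1` at 880 nM on the same read-out. Compound 3 `O=C1c2c[n+]([O-])c3ccccc3c2C(=O)c2c1c1ccccc1n2Cc1cn([C@H]2C[C@H](O)[C@@H](CO)O2)nn1` has not yet been measured, and its structure departs from that of compound 2 as follows: 4-hydroxy-5-(hydroxymethyl)oxolan-2-yl in place of (5-(hydroxymethyl)-2,2-dimethyl-1,3-dioxolan-4-yl)methyl on an aromatic nitrogen. The new group stands directly on an aromatic nitrogen of a five-membered aromatic ring with 3 nitrogen, and the dimethyl-bearing dioxolane ring is gone.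

Among the measured compounds shown here, only one measured step bears on this change: a 2.4-fold lower number from compound 1 to compound 2 (0.38 log units; beyond the scatter), a modest step that came with the arrival of that same dioxolane group in place of 1,2-dihydroxyethyl. Compound 3 gives that group up again, so a step of similar modest size towards a higher number is expected. For the measured compounds named here, the oxolane ring itself has no measured counterpart, which leaves this expectation loose. The estimate amounts to a 2.2-fold higher number from compound 2 to compound 3 (0.33 log units; beyond the scatter) as the expected step. Compound 3 is expected at 800 nM with an estimated range of 300 nM to 2200 nM in this assay.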

Compound 3, half-maximal inhibitory concentration: 350 nM
Beside the measured number, compound 3's estimate is 2.3-fold (0.36 log units) above it, within the range that was stated.
By their numbers in this assay, from the lowest: compounds 3 and 2 (each within the scatter of the next); then compound 1.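

In this assay the change gives a 1.1-fold lower number from compound 2 to compound 3 (0.02 log units; within the scatter), so the dimethyl-bearing dioxolane ring and its methyl link can be given up with no separation between the two compounds on this read-out. The 4-hydroxy-5-(hydroxymethyl)oxolan-2-yl group, which stands directly on the aromatic nitrogen, also shows a 2.5-fold lower number from compound 1 to compound 3 (0.40 log units; beyond the scatter), so among these three compounds both ring-bearing groups, in compound 2 and compound 3, stand apart from the open 2,3-dihydroxypropyl chain of compound 1, and none goes against this. No measurement is at hand that accounts for the two ring-bearing groups reading alike or for their difference from the open chain.

The compounds shown leave open whether the oxolane ring or its hydroxyl and hydroxymethyl groups carry this difference, and an oxolane without those groups would separate these parts. They also leave open how far this position tolerates other kinds of group, such as an amine or a carboxylic acid on the triazole-bound chain, or how the other stereoisomers of the oxolane compare.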